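The compounds below may be only part of what the source reports. "The series", "measured", "known", "first", "only" and "open" are said of these compounds alone.

Among the three compounds measured in a functional assay on Hs-578T cells (Homo sapiens) for inhibition, read by sulforhodamine B assay, with a stated time of 48 h (on this read-out lower numbers stand for stronger inhibition of growth and higher numbers for weaker inhibition of growth), compound 1 `Nc1cc(N)c2nc(-c3ccccc3)c(Oc3ccc(Cl)c(Cl)c3)nc2c1` stands lowest: in this assay compound 1 gives 10700 nM. Compound 3 `COc1ccc(CNc2nc3cc(N)cc(N)c3nc2-c2ccccc2)cc1` comes nearest, and in this assay compound 3 gives 26900 nM, a gap that lies beyond the scatter. Compound 2 `CCOC(=O)[C@H](CCC(=O)O)NC(=O)c1ccc(Oc2nc3cc(N)cc(N)c3nc2-c2ccccc2)cc1` is furthest away, and in this assay compound 2 gives 43700 nM, again beyond the scatter. On these numbers compound 1 is therefore the most potent of the three.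

Compound 4 `COc1ccc(Sc2nc3cc(N)cc(N)c3nc2-c2ccccc2)cc1` has not been measured. It differs from compound 1 in one place: (4-methoxyphenyl)sulfanyl in place of 3,4-dichlorophenoxy on an aromatic carbon. Among the measured compounds shown here, no pair of measured compounds shows this exact change, so its size can only be guessed. For the measured compounds named here, since the one other measured compound with a different group at that position, compound 3, gives 26900 nM, compound 4 is expected to fall short of compound 1, and the step from compound 1 to compound 4 is expected to be a 2.1-fold higher number from compound 1 to compound 4 (0.31 log units; beyond the scatter). For compound 4 the estimate in this assay is 22000 nM, with a range from 8000 nM to 60000 nM.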

Compound 4, concentration for 50% growth inhibition: < 100000 nM
Compound 4: no number, only a limit; the forecaster's own chance of this, stated with the estimate: 10%; the middle value is on the limit's open side.
By their numbers in this assay, from the lowest: compound 1; then compounds 3 and 2 (each within the scatter of the next).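

In this assay, among the compounds shown here, compound 4 gives < 100000 nM, which is a limit and not a number, so no step between compound 1 and compound 4 can be read. The compounds shown leave open how (4-methoxyphenyl)sulfanyl in place of 3,4-dichlorophenoxy changes growth inhibition, in direction or in size.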